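Adding a methoxy to the pendant phenyl of compound 2

A few compounds are considered here, and "the series" means these few. Any claim that something is new, unique, unknown or untested is made for them only; others in the source may bear on it.

Compound 2 `COc1cc(/C=C/C(=O)c2cccc(-n3cc(-c4ccccc4)[nH]c3=O)c2)ccc1O` is the reference point of this small set. In a functional assay on SNB-75 cells (Homo sapiens) for inhibition (on this read-out lower numbers stand for stronger inhibition of growth and higher numbers for weaker inhibition of growth), compound 2 gives 3900 nM, the lowest of the two numbers obtained; compound 3 `O=C(/C=C/c1cccc(O)c1)c1cccc(-n2cc(-c3ccccc3)[nH]c2=O)c1` gives 12100 nM, and the step of a 3.1-fold higher number from compound 2 to compound 3 (0.49 log units; beyond the scatter) concerns only the chain end, not the ring examined here. Compound 1 `COc1cc(/C=C/C(=O)c2cccc(-n3cc(-c4ccc(Cl)cc4)[nH]c3=O)c2)cc(OC)c1OC` differs from compound 2 both at that phenyl ring and on the chain. In this assay compound 1 gives "not active" (no number reported).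

Compound 4 `COc1ccc(-c2cn(-c3cccc(C(=O)/C=C/c4ccc(O)c(OC)c4)c3)c(=O)[nH]2)cc1` carries the change (methoxy in place of hydrogen on an aromatic carbon), so that the phenyl becomes 4-methoxyphenyl. Among the compounds with values here, no measured step touches this ring alone, and compound 1 cannot be read as such a step because two places differ at once. Without a precedent for this position, he expects the step of a 1.2-fold higher number from compound 2 to compound 4 (0.06 log units; within the scatter) to stay near the scatter, in either direction. His estimate for compound 4 in this assay is therefore 4500 nM, with a range from 1500 nM to 14000 nM.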

Compound 4, concentration for 50% growth inhibition: 4730 nM
Estimate against measurement, compound 4: 1.1-fold (0.02 log units) below; the measured number falls inside the stated range.
By their numbers in this assay, from the lowest: compounds 2 and 4 (each within the scatter of the next); then compound 3.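

Within the data shown here, the step of a 1.2-fold higher number from compound 2 to compound 4 (0.08 log units; within the scatter), read in this assay, is the first that touches this ring alone, and it shows that methoxy in place of hydrogen, para to a large group, gives a number within the scatter of the one for the unsubstituted phenyl. The earlier step, a 3.1-fold higher number from compound 2 to compound 3 (0.49 log units; beyond the scatter), concerned only the chain end, so the phenyl-to-4-methoxyphenyl change now has a reading of its own, and at this position it is far smaller than that chain-end step. Nothing available here bears on why this change has so little effect on the number.

As far as these compounds go, whether an amine or a carboxylic acid at the same position would also stay within the scatter remains open. Also open, from the compounds shown here alone, is how much of the result for compound 1 , "not active" (no number reported), comes from the chlorine on its ring and how much from its chain end.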